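This account rests on a few compounds, and the source may have more. Where it says the series, first, only, none or still open, it means among the compounds named here.

Of the compounds shown here, three built on one shared core have been tested in an ADME assay on RAW264.7 cells (Mus musculus) for cytotoxicity, read by MTT assay, with a stated time of 48 h; a higher number here means that more compound is tolerated, a lower number that less compound is tolerated. Compound 1 `C#CCN(c1nc(-c2cccc(C)c2)no1)C1CCCCC1` gives 25.9 ug/mL. Compound 3 `C#CCN(c1nc(-c2ccccc2)no1)C1CCCCC1` carries hydrogen in place of methyl on an aromatic carbon and gives 32.1 ug/mL; the step between them is a 1.2-fold higher number from compound 1 to compound 3 (0.09 log units; within the scatter). Compound 2 `CC(=O)OC[C@H]1O[C@H](OC[C@@H](Cn2cc(CN(c3nc(-c4ccccc4)no3)C3CCCCC3)nn2)OC(C)=O)C=C[C@@H]1OC(C)=O`, the starting point of the step followed here, gives 28.6 ug/mL in this assay, a number that differs from those of compound 1 and of compound 3 by less than the usual scatter, so the three compounds stand together and nothing separates one from another.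

Compound 4 `CC(=O)OC[C@H]1O[C@H](OC[C@@H](Cn2cc(CN(c3nc(-c4ccc([N+](=O)[O-])cc4)no3)C3CCCCC3)nn2)OC(C)=O)C=C[C@@H]1OC(C)=O` is the next compound to be measured. It differs from compound 2 in a single place: nitro in place of hydrogen on an aromatic carbon. Within the data shown here, only one measured step changes a substituent on that aromatic ring, the step of a 1.2-fold higher number from compound 1 to compound 3 (0.09 log units; within the scatter), and it exchanges methyl for hydrogen rather than hydrogen for nitro, so it is a loose guide at best. Among the measured compounds shown here, with no closer precedent among the measured compounds, compound 4 is expected to give 25 ug/mL in this assay, within a range of 12 ug/mL to 50 ug/mL. That estimate means a step of a 1.1-fold lower number from compound 2 to compound 4 (0.06 log units; within the scatter), which is expected to stay within the scatter.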

Compound 4, half-maximal cytotoxic concentration: 64.1 ug/mL
Estimate against measurement, compound 4: 2.6-fold (0.41 log units) below; measured number above the stated range.
By their numbers in this assay, from the lowest: compounds 1, 2, 3 and 4 (each within the scatter of the next, the first and the last beyond it).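

In this assay, the change from phenyl to 4-nitrophenyl gives a 2.2-fold higher number from compound 2 to compound 4 (0.35 log units; beyond the scatter), a modest rise and the only step among these compounds that lies beyond the scatter. The earlier step on an aromatic ring, a 1.2-fold higher number from compound 1 to compound 3 (0.09 log units; within the scatter), had shown no readable change, whereas this result shows that a substituent on an aromatic carbon, here para to a large group, can shift the number towards more compound being tolerated. No measurement available here bears on why the number rises, so the result stands as an observation only.

Going by these compounds, whether the rise belongs to nitro itself or would also come with another group at this place, such as an amine or a carboxylic acid, remains open, as does the outcome of moving nitro elsewhere on the ring. On these data alone, it is also open whether nitro would give a similar step on compound 3 , which lacks the large group carried by compound 2 , or whether the step holds only in this larger setting.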